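The source may hold more compounds than are shown below. What is called first, only, known or untested is meant among the compounds shown, and "the series" means these compounds.

Three measured compounds share one core and differ only in the group carried on the aromatic carbon two atoms from the ring nitrogen. Compound 1 `CCCN(CCC)c1cc(C)nc2c(-c3ncc([N+](=O)[O-])cc3C)c(C)nn12` carries a nitro group there and gives 9.1 nM in an assay on isolated protein for binding affinity to corticotropin-releasing factor receptor 1 (Homo sapiens); a higher number here means a weaker inhibitor, a lower number a stronger inhibitor. Compound 2 `CCCN(CCC)c1cc(C)nc2c(-c3ncc(N)cc3C)c(C)nn12` carries an amino group and gives 85 nM in this assay. Compound 3 `CCCN(CCC)c1cc(C)nc2c(-c3ncc(N4CCCCC4)cc3C)c(C)nn12` carries a piperidin-1-yl group and gives 17 nM in this assay. Among these three numbers compound 3 holds the second highest; its nearest neighbour is compound 1, a 1.9-fold higher number from compound 1 to compound 3 (0.27 log units; within the scatter), and its furthest is compound 2, a 5.0-fold lower number from compound 2 to compound 3 (0.70 log units; beyond the scatter).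

Compound 4 `CCCN(CCC)c1cc(C)nc2c(-c3ncc(O)cc3C)c(C)nn12` is the unmeasured member. Its change from compound 3 is hydroxy in place of piperidin-1-yl on an aromatic carbon. Among the compounds with values here, the measured step that bears most directly on this change is the one from compound 2 to compound 3, a 5.0-fold lower number from compound 2 to compound 3 (0.70 log units; beyond the scatter), where a single-atom group with a hydrogen-bond donor was replaced by the piperidin-1-yl ring. Compound 4 reverses that kind of change: a ring leaves and a single-atom group with one hydrogen-bond donor and one acceptor enters. The step from compound 1 to compound 2, a 9.3-fold higher number from compound 1 to compound 2 (0.97 log units; beyond the scatter), also shows that a small donor group at this position sat at the high end of the set.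

It is therefore expected that compound 4 gives a higher number than compound 3, with a step of roughly the size seen between compound 2 and compound 3, so that a 4.1-fold higher number from compound 3 to compound 4 (0.61 log units; beyond the scatter) is estimated. Compound 4 is estimated at 70 nM in this assay, with a range from 25 nM to 200 nM.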

Compound 4, inhibition constant: 530 nM
Compound 4: the middle estimate sits 7.6-fold (0.88 log units) below what was measured; the measured number lies above the stated range.
By their numbers in this assay, from the lowest: compounds 1 and 3 (each within the scatter of the next); then compound 2; then compound 4.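

In this assay hydroxy does not behave like amino at this position, although both are single-atom groups with a hydrogen-bond donor: a 6.2-fold higher number from compound 2 to compound 4 (0.79 log units; beyond the scatter), so a small donor group does not by itself fix the number here. The loss of the piperidin-1-yl ring costs more than the earlier amino comparison showed, with a 31-fold higher number from compound 3 to compound 4 (1.49 log units; beyond the scatter), and the distance from the nitro compound is wider still, with a 58-fold higher number from compound 1 to compound 4 (1.77 log units; beyond the scatter), which leaves compound 4 as the weakest of the four, its steps to all the others lying beyond the scatter. No measurement available here accounts for the gap between hydroxy and amino or for the size of these steps.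

The compounds shown leave open whether the gap follows the oxygen atom itself or the hydrogen on it, a question that a methoxy group in the same place would address. They also leave open where a morpholin-4-yl ring or a carboxylic acid would fall relative to compound 1 and compound 3, whose numbers lie within the scatter of each other.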